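Replacing Phenyl with 4-Methoxybenzyl: What to Expect

A few compounds are considered here, and "the series" means these few. Any claim that something is new, unique, unknown or untested is made for them only; others in the source may bear on it.

Three related compounds have been tested so far in a functional assay on MDA-MB-231 cells (Homo sapiens) for inhibition, read by CCK-8 assay, with a stated time of 48 h; on this read-out lower numbers stand for stronger inhibition of growth and higher numbers for weaker inhibition of growth. Compound 1 (`Cc1ccccc1Nc1nc(Nc2ccccn2)ncc1Cl`) gives 11200 nM, compound 2 (`Cc1ccccc1Nc1nc(Nc2cc(Cl)ccn2)ncc1Cl`) gives 52400 nM, and compound 3 (`CN1CCN(c2ccc(Nc3ncc(Cl)c(Nc4ccccc4)n3)nc2)CC1`) gives 37400 nM. Compound 3 thus lies within the usual scatter of compound 2, while its number is higher than that of compound 1 by more than the scatter, which means weaker inhibition of growth.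

Compound 4 (`COc1ccc(CNc2nc(Nc3ccc(N4CCN(C)CC4)cn3)ncc2Cl)cc1`) has not yet been measured. It differs from compound 3 in one place: 4-methoxybenzyl in place of phenyl on a nitrogen on an aromatic ring. Put another way, anilino becomes (4-methoxybenzyl)amino.

Within the data shown here, the only measured step between compounds differing in one place is a 4.7-fold higher number from compound 1 to compound 2 (0.67 log units; beyond the scatter), a modest one that comes from chloro in place of hydrogen on an aromatic carbon. Among the measured compounds shown here, that is a different change, so it offers no direct guide here, and no measurement yet shows what altering the group on this nitrogen does. With no direction supported by the data, no step beyond the scatter is expected in this assay. The estimated step is a 1.2-fold lower number from compound 3 to compound 4 (0.10 log units; within the scatter). For compound 4, the expected value is 30000 nM, with an estimated range from 9000 nM to 90000 nM.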

Compound 4, concentration for 50% growth inhibition: 14900 nM
The estimate for compound 4 lay 2.0-fold (0.30 log units) above the measured number; low and high end bracket the measured number.
By their numbers in this assay, from the lowest: compounds 1 and 4 (each within the scatter of the next); then compounds 3 and 2 (each within the scatter of the next).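

Among these compounds, the group on this nitrogen does matter: in this assay, 4-methoxybenzyl in place of phenyl gives a 2.5-fold lower number from compound 3 to compound 4 (0.40 log units; beyond the scatter), a modest step toward stronger inhibition of growth and the first measured change at this position. The position therefore accepts a larger group, with 9 heavy atoms instead of 6, without losing activity in this assay, and the entering group also brings one hydrogen-bond acceptor that phenyl lacks. The change bundles two differences, the methoxy group and the carbon link between the ring and the nitrogen, and nothing measured here explains why the number falls.

The compounds shown leave open which of those two differences carries the step: a plain benzyl group on the same nitrogen would separate the methoxy group from the link, and a phenethyl group would show whether a longer chain goes further in the same direction. Also open, on these data alone, is whether the same change would give a similar step on the other compounds, whose remaining groups differ from those of compound 3.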